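Methoxy on the benzothiazole of compound 3

The source may hold more compounds than are shown below. What is called first, only, known or untested is meant among the compounds shown, and "the series" means these compounds.

Going by the values given here, compound 3 `O=C(CNC(=O)c1nn(-c2ccccc2)c(=O)c2ccccc12)Nc1nc2ccccc2s1` is the only member of this set with a measured number: in an assay on L cells for inhibition of Protein-serine O-palmitoleoyltransferase porcupine (Mus musculus), read by reporter gene assay, with a stated time of 24 h (a lower number here means that less compound is needed, a higher number that more compound is needed for the effect), compound 3 gives 2600 nM. Compound 1 `O=C(CNC(=O)c1nn(-c2ccc(F)cc2)c(=O)c2ccccc12)Nc1nc2ccccc2s1` reaches only the limit of the assay, > 25000 nM, in this assay. Compound 2 `O=C(CNC(=O)c1nn(-c2ccccc2)c(=O)c2ccccc12)Nc1nccs1` likewise sits at the limit, > 25000 nM, in this assay. As far as these compounds go, the two measured steps are therefore both bounded from one side: an at least 9.6-fold lower number from compound 1 to compound 3 (0.98 log units; beyond the scatter), and an at least 9.6-fold lower number from compound 2 to compound 3 (0.98 log units; beyond the scatter); both rest on (the limit of > 25000 nM in this assay, at which 2 of the 3 values shown sit), so their true size is unknown.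

Compound 4 `COc1ccc2nc(NC(=O)CNC(=O)c3nn(-c4ccccc4)c(=O)c4ccccc34)sc2c1` differs from compound 3 in one place: methoxy in place of hydrogen on an aromatic carbon. Neither measured step touches this position or this group. The step from compound 1 to compound 3 concerns a fluoro on the other aryl ring, and the step from compound 2 to compound 3 concerns the replacement of 1,3-thiazol-2-yl by 1,3-benzothiazol-2-yl, the very ring that now carries the methoxy. The record shows that changes to the rings can shift the number by at least modest amounts, but gives no direction for a methoxy here. The expected step is therefore small, a 1.4-fold lower number from compound 3 to compound 4 (0.16 log units; within the scatter), with wide uncertainty in both directions. Compound 4 is estimated at 1800 nM in this assay, within 350 nM to 9000 nM.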

Compound 4, half-maximal effective concentration: 210 nM
Compound 4: middle estimate off by 8.6-fold (0.93 log units), on the high side, outside the stated range (below it).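

In this assay, the position is far from silent: methoxy on the six-membered aromatic ring of carbon only, within the 6-methoxy-1,3-benzothiazol-2-yl group, gives a 12-fold lower number from compound 3 to compound 4 (1.09 log units; beyond the scatter). Going by these compounds alone, this is the first step with a measured number at both ends, so it gives both a direction and a size for a substituent on the 1,3-benzothiazol-2-yl group itself, which the earlier one-sided steps could not do. Counted from the 1,3-thiazol-2-yl group, the change reads an at least 110-fold lower number from compound 2 to compound 4 (2.07 log units; beyond the scatter), and this size is only a bound: the limit of > 25000 nM in this assay, at which 2 of the 4 values shown sit.

The compounds shown do not settle whether the step belongs to methoxy itself or would also appear with another group at the same place, such as hydroxy, ethoxy, chloro or an amine. Also open, as far as these compounds go, is whether the methoxy step carries over to the core of compound 1, with its fluoro on the other aryl ring.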